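The source may hold more compounds than are shown below. What is called first, only, known or untested is meant among the compounds shown, and "the series" means these compounds.

Three compounds carry the shared core of compound 1 `COc1ccccc1-c1cn(-c2ccc(O)c(C(=O)Nc3cccc(C(F)(F)F)c3)c2)nn1` into a functional assay on CCRF-CEM cells (Homo sapiens) for inhibition, read by MTT assay, with a stated time of 2 days, tested at 10 uM (a lower number here means less inhibition, a higher number more inhibition at the concentration tested (going by the name of the read-out)), and compound 1 stands at the top of the three numbers: in this assay compound 1 gives 65%. The nearest is compound 3 `COC(=O)c1cc(-n2cc(-c3cc(O)ccc3O)nn2)ccc1O`, which in this assay gives 52%, a gap beyond the usual scatter, so the number for compound 1 is the highest of the three. Furthest away is compound 2 `COc1ccc(OC)c(-c2cn(-c3ccc(O)c(C(=O)OCCCc4ccccc4)c3)nn2)c1`, which in this assay gives 5%, far below compound 1 and again beyond the scatter. For the measured compounds named here, compound 2 carries an ester on the core and a dimethoxyphenyl group on the five-membered ring, whereas compound 1 carries an amide to a trifluoromethylphenyl group; no two of the measured compounds differ in one place only, so no single structural step has been measured.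

Compound 4 `O=C(Nc1cccc(C(F)(F)F)c1)c1cc(-n2cc(-c3cccc(O)c3)nn2)ccc1O` keeps the amide of compound 1 and changes the group on the five-membered ring: 3-hydroxyphenyl in place of 2-methoxyphenyl on an aromatic carbon. Going by the values given here, nothing among the measured compounds shows what this exchange does; the measured gaps all involve several changes at once. The expectation is a small loss, within or near the scatter, with the step from compound 1 to compound 4 estimated as a number 10 percentage points lower from compound 1 to compound 4 (within the scatter). Compound 4 is expected to give about 55% in this assay, in a range from 30% to 75%.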

Compound 4, a percentage reported as inhibition, at one concentration (the size of the read-out at that concentration, not a potency): 13%
The estimate for compound 4 lay 42 percentage points above the measured number; the whole stated range lies above it.
By their numbers in this assay, from the lowest: compounds 2 and 4 (each within the scatter of the next); then compound 3; then compound 1.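

In this assay the group on the five-membered ring proves to matter: with the amide to the trifluoromethylphenyl group held fixed, putting 3-hydroxyphenyl in place of 2-methoxyphenyl gives a number 52 percentage points lower from compound 1 to compound 4 (beyond the scatter) and is the first change in one place only among the compounds shown. For the compounds shown here, a fall in the number can therefore be tied to this position alone for the first time, rather than to several differences at once. The exchange still alters two things together, the oxygen-bearing group and its place on the phenyl ring, with a hydrogen-bond donor entering where none stood before, and nothing available here explains the loss.

On these data alone, a 3-methoxyphenyl or a 2-hydroxyphenyl group at this position, on the same amide, would pull those two changes apart, so it remains open whether the hydroxyl group itself or its place on the ring goes with the lower number. As far as these compounds go, it also remains open how a plain phenyl group or an aminophenyl group would behave at this position.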